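Aryl Swaps on a Ring Amine Nitrogen: Adenosine Receptor Binding

A few compounds are considered here, and "the series" means these few. Any claim that something is new, unique, unknown or untested is made for them only; others in the source may bear on it.

Measured compounds:
compound 1 `Nc1scc(CN2CCN(c3cc(Cl)cc(Cl)c3)CC2)c1C(=O)c1ccc(Cl)cc1`: 1%
compound 2 `Nc1scc(CN2CCN(C3CCCCCC3)CC2)c1C(=O)c1ccc(Cl)cc1`: 0%
compound 3 `Nc1scc(CN2CCN(c3c(F)cc(F)cc3F)CC2)c1C(=O)c1ccc(Cl)cc1`: 0%

All three numbers come from an assay on CHO cells for displacement of a labelled ligand from adenosine receptor A1 (Homo sapiens), read by scintillation counting, with a stated time of 120 min, tested at 10 uM; on this read-out lower numbers stand for less inhibition and higher numbers for more inhibition at the one concentration tested (going by the name of the read-out). Compound 3 stands level with compound 2 at the digits printed, the two together at the bottom of the three, and compound 1 sits only a number 1 percentage points lower from compound 1 to compound 3 (within the scatter) away. Compound 4 is `Nc1scc(CN2CCN(c3ccc(Cl)c(Cl)c3)CC2)c1C(=O)c1ccc(Cl)cc1`; it differs from compound 3 by 3,4-dichlorophenyl in place of 2,4,6-trifluorophenyl on an amine nitrogen in a ring. Among the compounds with values here, the steps that bear on this change are the earlier swaps on the same nitrogen: a number 1 percentage points lower from compound 1 to compound 2 (within the scatter), a number 1 percentage points lower from compound 1 to compound 3 (within the scatter) and no change at the digits printed from compound 2 to compound 3 (within the scatter), none beyond the scatter. Compound 4 is therefore expected to move by a number 1 percentage points higher from compound 3 to compound 4 (within the scatter), no real step in either direction. The estimate for compound 4 is 1%, within -5% to 10%.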

Compound 4, a percentage reported as inhibition, at one concentration (the size of the read-out at that concentration, not a potency): 1%
For compound 4 middle estimate and measured number coincide at the digits printed, within the range that was stated.
By their numbers in this assay, from the lowest: compounds 2, 3, 1 and 4 (each within the scatter of the next).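

In this assay, 3,4-dichlorophenyl on the amine nitrogen in a ring reads the same as 3,5-dichlorophenyl (no change at the digits printed from compound 1 to compound 4 (within the scatter)), so this new chlorine pattern gives no step beyond the scatter. Nor does it stand apart from the other two groups at this nitrogen (a number 1 percentage points higher from compound 3 to compound 4 (within the scatter); a number 1 percentage points higher from compound 2 to compound 4 (within the scatter)). No supporting measurement is available to explain this flat result.

The compounds shown leave open whether a benzyl group, a carboxylic acid or a longer chain on this nitrogen would give a real step. They also leave open whether changing the 4-chlorophenyl ketone of the shared core would do so.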